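The source may hold more compounds than are shown below. What is called first, only, known or untested is meant among the compounds shown, and "the series" means these compounds.

Measured compounds:
- Compound 1, `CN1C[C@@H](c2ccc(Cl)cc2)[C@@]2(Cc3ccccc3C2=O)[C@@]12C(=O)Nc1ccccc12`: 63.4%
- Compound 2, `COc1ccc([C@@H]2CN(C)[C@]3(C(=O)Nc4ccccc43)[C@]23Cc2ccccc2C3=O)cc1`: 33.3%

Compound 1 and compound 2 share one core and differ only in the group carried on the aromatic ring. In a functional assay on RPMI18226 cells (Homo sapiens) for antiproliferative activity, read by sulforhodamine B assay, with a stated time of 48 h, tested at 10 uM (on this read-out lower numbers stand for less inhibition and higher numbers for more inhibition at the one concentration tested (going by the name of the read-out)), compound 1 gives 63.4%, while compound 2 gives 33.3%. Within the data shown here, the single step measured so far, a number 30.1 percentage points lower from compound 1 to compound 2 (beyond the scatter), is the only comparison in hand, and on it compound 2 stands lowest of the two numbers, with compound 1 as its nearest neighbour.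

Compound 3, `CN1C[C@@H](c2cccs2)[C@@]2(Cc3ccccc3C2=O)[C@@]12C(=O)Nc1ccccc12`, has not yet been measured in this assay. It differs from compound 2 as follows: thiophen-2-yl in place of 4-methoxyphenyl on a saturated ring carbon. Among the measured compounds shown here, no measured step exchanges an aromatic ring for another of a different kind, so the one known step only shows that the group at this place can move the read-out by a large amount. On that basis the expected step is a number 11.7 percentage points higher from compound 2 to compound 3 (beyond the scatter), a rise toward the number of compound 1, though with wide uncertainty. Compound 3 is therefore estimated at 45%, within a range from 20% to 70%.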

Compound 3, a percentage reported as inhibition, at one concentration (the size of the read-out at that concentration, not a potency): 10.9%
The estimate for compound 3 lay 34.1 percentage points above the measured number; measured number outside the range, below it.
By their numbers in this assay, from the lowest: compound 3; then compound 2; then compound 1.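

At this position the change is no longer confined to a substituent on a phenyl ring: the aromatic ring itself is exchanged, and in this assay this gives a number 22.4 percentage points lower from compound 2 to compound 3 (beyond the scatter) and a number 52.5 percentage points lower from compound 1 to compound 3 (beyond the scatter). Compound 3, with thiophen-2-yl on the saturated ring carbon, therefore lies beyond the scatter below both phenyl-bearing compounds, so among these three the read-out depends on the kind of aromatic ring as well as on the group carried by a phenyl ring, and the larger of the two steps starts from the 4-chlorophenyl compound. Nothing available on these compounds accounts for the fall in inhibition that comes with this exchange.

The three compounds leave open whether the lower number goes with the five-membered ring, with its sulfur atom or with the absence of a chloro or methoxy group, a question that furan-2-yl, an unsubstituted phenyl ring or a chloro group on the thiophene ring would bear on. They also leave open how a pyridine ring, or a phenyl ring carrying an amine or a carboxylic acid, would read at this position.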